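The compounds below may be only part of what the source reports. "The series", "measured", "known", "first", "only" and "open" are said of these compounds alone.

Measured compounds:

compound 1, `ClCc1ccccc1Cn1cnc2c(Cl)nc(Cl)nc21`, with 8510 nM in a functional assay on UACC-257 cells (Homo sapiens) for cytotoxicity, read by sulforhodamine B assay, with a stated time of 48 h; a lower number here means that less compound is tolerated, a higher number that more compound is tolerated
compound 2, `ClCc1ccccc1Cn1cnc2c(Cl)ncnc21`, with 66100 nM in this assay
compound 3, `ClCc1ccccc1Cn1cnc2ncnc(Cl)c21`, with 61700 nM in this assay

Compounds 1 and 2 share one core, and compound 3 is built on another; the difference between the two cores is not broken down here, the two cores simply hold the same atoms joined differently. Compound 3 and compound 2 give numbers that lie within the usual scatter of one another, so nothing separates them.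

Within the first core, one change has been measured: compound 1 differs from compound 2 by chloro in place of hydrogen on an aromatic carbon. That change gave a 7.8-fold lower number from compound 2 to compound 1 (0.89 log units; beyond the scatter), a step beyond the scatter, so compound 1 is tolerated at a clearly lower concentration than compound 2.

The unmeasured compound 4, `ClCc1ccccc1Cn1cnc2nc(Cl)nc(Cl)c21`, stands to compound 3 as compound 1 stands to compound 2: it differs by chloro in place of hydrogen on an aromatic carbon, and the surroundings of the entering chloro group are described in the same words as before, so it is the same change on the other core. Among the measured compounds shown here, only this single earlier example supports a forecast, and how the second core responds is unknown. Resting on the step from compound 2 to compound 1 and on the value of compound 3, the expected step is a 6.9-fold lower number from compound 3 to compound 4 (0.84 log units; beyond the scatter). Compound 4 is therefore estimated at 9000 nM in this assay, with a likely range from 3000 nM to 30000 nM.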

Compound 4, concentration lethal to 50% of the cells: 8700 nM
Compound 4: the middle estimate sits 1.0-fold (0.01 log units) above what was measured; the range from low to high includes it.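

Placing the chloro group on the second core gave a 7.1-fold lower number from compound 3 to compound 4 (0.85 log units; beyond the scatter) in this assay, so the change carried over from one core to the other, and its size held as well: the same change on two cores in this assay, a 7.8-fold lower number (0.89 log units; beyond the scatter) from compound 2 to compound 1 and a 7.1-fold lower number (0.85 log units; beyond the scatter) from compound 3 to compound 4, 1.1-fold (0.04 log units) apart, within the scatter of two such steps

For these two pairs, then, chloro in place of hydrogen on an aromatic carbon lowers the number by much the same amount on either core, and a step measured on one core proved a fair guide to the other. Two pairs remain a small base, however: they do not show why the step arises, whether a third core would respond alike, or whether cells other than those tested here would behave the same way.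

The compounds shown leave open whether another group in that same place, such as an amine, a methoxy group or a bromo group, would give a step of similar size. Going by these compounds, all four compounds also carry the same chloromethyl group, so what a plain methyl or a hydroxymethyl group would do in its stead remains open too.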